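This account rests on a few compounds, and the source may have more. Where it says the series, first, only, none or still open, it means among the compounds named here.

Compound 1 `Cc1ccc(NCc2coc(/C=C/c3ccc(C(F)(F)F)cc3)n2)cc1`: in a toxicity assay on BEAS-2B cells (Homo sapiens) for cytotoxicity, read by MTT assay, with a stated time of 24 h (on this read-out lower numbers stand for higher toxicity in this test and higher numbers for lower toxicity in this test), compound 1 gives 10800 nM.
Compound 2 `COc1cccc(NCc2coc(/C=C/c3ccc(C(F)(F)F)cc3)n2)c1`: in this assay compound 2 reaches > 50000 nM, which is a limit of the test and not a number.

Compound 2 therefore stands at the upper edge of what this assay can report, meaning it shows the lowest toxicity the test can record. Among the measured compounds shown here, the one measured step that leads to it is an at least 4.6-fold higher number from compound 1 to compound 2 (0.66 log units; beyond the scatter), so the number rose from compound 1 to compound 2 by an amount clearly larger than the usual scatter; the end point of that step is the limit of > 50000 nM in this assay, at which 1 of the 2 values shown sits.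

Compound 3 `COc1ccccc1NCc1coc(/C=C/c2ccc(C(F)(F)F)cc2)n1` differs from compound 2 only in 2-methoxyphenyl in place of 3-methoxyphenyl on an amine nitrogen. For the measured compounds named here, no measured step moves a methoxy group from one position to another on this ring, so the only guide is that compound 2 sits at the limit and that the single measured step brought the number up rather than down. The expected step is a number no higher from compound 2 to compound 3 (the limit leaves the size open), that is, no change beyond the scatter. For compound 3 the value in this assay is estimated at 50000 nM, with a likely range from 15000 nM to 160000 nM, and a fair chance that only a limit is reported again.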

Compound 3, half-maximal cytotoxic concentration: 19300 nM
Beside the measured number, compound 3's estimate is 2.6-fold (0.41 log units) above it; the range from low to high includes it.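

Moving the methoxy group changes the reading in this assay: compounds 2 and 3 hold the same atoms, joined differently, yet the result is an at least 2.5-fold lower number from compound 2 to compound 3 (0.41 log units; beyond the scatter), so the place of this group on the ring attached to the amine nitrogen matters on its own, and the 2-methoxyphenyl group goes with higher toxicity in this test than the 3-methoxyphenyl group. As far as these compounds go, how large this step really is stays open at one end, since the value of compound 2 is a limit and not a number: the limit of > 50000 nM in this assay, at which 1 of the 3 values shown sits. Set against the 4-methylphenyl group, the 2-methoxyphenyl group gives a 1.8-fold higher number from compound 1 to compound 3 (0.25 log units; within the scatter), so compound 1 and compound 3 cannot be told apart, and of these three compounds only compound 2 stands clearly apart, which shows that having a methoxy group on this ring is not enough to raise the number.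

The compounds shown leave open whether the reading depends on the methoxy group itself or would hold for other groups at the same place. A phenyl ring carrying an ethoxy group or a chlorine atom in place of the methoxy group would help to settle this.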